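Chain amines on the shared core: expectation for compound 4

A few compounds are considered here, and "the series" means these few. Any claim that something is new, unique, unknown or untested is made for them only; others in the source may bear on it.

Measured so far:
compound 1 `COc1ccccc1-c1cc(C2CCNC2)ccc1Cl`: 970 nM
compound 2 `CCNCc1ccc(Cl)c(-c2ccccc2OC)c1`: 1800 nM
compound 3 `COc1ccccc1-c1cc(CN(C)C)ccc1Cl`: 220 nM

Three compounds share the core of compound 1 and differ only in the amine-bearing group on the aromatic carbon. In an assay on isolated protein for binding affinity to 5-hydroxytryptamine receptor 5A (Homo sapiens) (on this read-out lower numbers stand for stronger inhibition and higher numbers for weaker inhibition), compound 1 gives 970 nM, the second highest of the three numbers. Its nearest neighbour is compound 2 with 1800 nM; that step is a 1.9-fold higher number from compound 1 to compound 2 (0.27 log units; within the scatter). Its furthest neighbour is compound 3 with 220 nM; that step is a 4.4-fold lower number from compound 1 to compound 3 (0.64 log units; beyond the scatter). Between the two chain amines the step is an 8.2-fold lower number from compound 2 to compound 3 (0.91 log units; beyond the scatter).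

Compound 4 `CCN(CC)Cc1ccc(Cl)c(-c2ccccc2OC)c1` has not yet been measured in this assay. Relative to compound 1 the change is (diethylamino)methyl in place of pyrrolidin-3-yl on an aromatic carbon.

Among the compounds with values here, two measured steps bear on it. Within the data shown here, the step from compound 1 to compound 3 is the closest precedent, since it also exchanges the ring amine for a chain amine with no ring and no hydrogen-bond donor, and it was modest and beyond the scatter. The step from compound 2 to compound 3 shows that among chain amines the one without a donor gave the lower number. A modest step downward is therefore expected, probably not larger than a 4.4-fold lower number from compound 1 to compound 3 (0.64 log units; beyond the scatter). Compound 4 is expected to give 400 nM, with a range of 150 nM to 1200 nM. That estimate means an expected step of a 2.4-fold lower number from compound 1 to compound 4 (0.38 log units; beyond the scatter).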

Compound 4, inhibition constant: 230 nM
The estimate for compound 4 lay 1.7-fold (0.24 log units) above the measured number; the measured number falls inside the stated range.
By their numbers in this assay, from the lowest: compounds 3 and 4 (each within the scatter of the next); then compounds 1 and 2 (each within the scatter of the next).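

Working notes on the amine-bearing group: with (diethylamino)methyl in place of pyrrolidin-3-yl, this assay gives a 4.2-fold lower number from compound 1 to compound 4 (0.63 log units; beyond the scatter), and diethylamino in place of dimethylamino gives a 1.0-fold higher number from compound 3 to compound 4 (0.02 log units; within the scatter), so at this position the added chain carbons on a fully substituted amine nitrogen produce no readable change, a tolerance that the earlier compounds could not show. The step from the secondary amine, ethyl in place of hydrogen on the amine nitrogen, is a 7.8-fold lower number from compound 2 to compound 4 (0.89 log units; beyond the scatter), so a second fully substituted chain amine now stands beyond the scatter from compound 2, and the low number no longer rests on compound 3 alone. No supporting measurement bears on why these numbers fall as they do.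

The compounds shown leave open whether the distance of compound 1 from compounds 3 and 4 follows from the ring, the amine hydrogen or the link to the aromatic carbon, and a pyrrolidin-1-ylmethyl group would hold the ring while removing that hydrogen. Going by these compounds, how far the flat response extends is also open, as dipropylamino or a bulkier diisopropylamino group on the same methylene would test it.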